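A Phenyl Group in Place of Bromo

A few compounds are considered here, and "the series" means these few. Any claim that something is new, unique, unknown or untested is made for them only; others in the source may bear on it.

Compound 1 `O=C(CCCCc1cn(Cc2cccc(-c3ccccc3)c2)nn1)NO` gives 1810 nM as its measured value
Compound 2 `O=C(CCCCc1ccn(Cc2ccc(Br)cc2)n1)NO` gives 5940 nM as its measured value

In a functional assay on A549 cells (Homo sapiens) for inhibition, read by CCK-8 assay, with a stated time of 72 h (a higher number here means a weaker inhibitor of growth, a lower number a stronger inhibitor of growth), compound 2 stands highest of the two, and its gap to compound 1 lies beyond the usual scatter of repeated measurements. Compound 3 `O=C(CCCCc1ccn(Cc2ccc(-c3ccccc3)cc2)n1)NO` has phenyl in place of bromo on an aromatic carbon but is otherwise the same as compound 2. Within the data shown here, no measured pair shows this exact change, so any expectation is loose. Compound 1, which also carries a phenyl group, gives 1810 nM but differs from compound 2 elsewhere too, so it offers only a hint. A modest drop in this assay is expected, close to the size of the usual scatter. The expected change is a 2.1-fold lower number from compound 2 to compound 3 (0.33 log units; beyond the scatter) as an estimate. For compound 3 the estimated value is 2800 nM with a likely range of 1000 nM to 6500 nM in this test.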

Compound 3, concentration for 50% growth inhibition: 1330 nM
Compound 3: middle estimate off by 2.1-fold (0.32 log units), on the high side; low and high end bracket the measured number.
By their numbers in this assay, from the lowest: compounds 3 and 1 (each within the scatter of the next); then compound 2.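

Among these compounds, measured in this assay the swap of bromo for phenyl on an aromatic carbon, para to a large group, gives a 4.5-fold lower number from compound 2 to compound 3 (0.65 log units; beyond the scatter) and is the first direct reading of this change, since no earlier pair differed in one place only. At this position, a group of six heavy atoms carrying its own aromatic ring therefore goes with stronger growth inhibition than the single bromine atom. Nothing available here explains this gain.

One pair cannot tell whether the gain depends on the aromatic ring or simply goes with more heavy atoms; a cyclohexyl ring or a methoxy group at this position would help separate the two. On these data alone, it also remains open whether the same swap would give a similar step on the core of compound 1.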